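Aryl amine swap on the shared core: bromine for methoxy

The source may hold more compounds than are shown below. What is called first, only, known or untested is meant among the compounds shown, and "the series" means these compounds.

Compound 1 `COc1ccc(Nc2nc(-c3cccc(F)c3)nc3ccc(F)cc23)cc1`; in a functional assay on U-937 cells (Homo sapiens) for cytotoxicity, read by MTT assay, with a stated time of 48 h (a lower number here means a stronger inhibitor, a higher number a weaker inhibitor), compound 1 gives 41100 nM.
Compound 2 `Fc1cccc(-c2nc(Nc3ccc(Cl)cc3)c3cc(F)ccc3n2)c1`; in this assay compound 2 gives 32700 nM.
Compound 3 `Fc1cccc(-c2nc(Nc3cccc(Cl)c3)c3cc(F)ccc3n2)c1`; in this assay compound 3 reaches only the assay limit, > 50000 nM.

Compound 1 and compound 2 sit within the scatter of each other: a 1.3-fold lower number from compound 1 to compound 2 (0.10 log units; within the scatter). Of the two numbers actually measured, compound 1 carries the higher figure, but that gap is within scatter. Compound 3 stands at the limit of the assay, (the limit of > 50000 nM in this assay, at which 1 of the 3 values shown sits). Against compound 1 this reads an at least 1.2-fold higher number from compound 1 to compound 3 (0.08 log units; that floor lies within the scatter), and against compound 2 an at least 1.5-fold higher number from compound 2 to compound 3 (0.18 log units; that floor lies within the scatter); both floors lie within the scatter, so the true number for compound 3 is not known, only that it is at or beyond the limit.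

Compound 4 `Fc1cccc(-c2nc(Nc3cccc(Br)c3)c3cc(F)ccc3n2)c1` differs from compound 1 by 3-bromophenyl in place of 4-methoxyphenyl on a nitrogen on an aromatic ring. Among the measured compounds shown here, the measured step that bears most closely on it is the one to compound 3, where 3-chlorophenyl in the same place ended at the limit. On that basis the step from compound 1 to compound 4 is expected to run upward, a 1.6-fold higher number from compound 1 to compound 4 (0.20 log units; within the scatter), with a real chance that compound 4 is also reported only as a limit. The estimate for compound 4 is 65000 nM, with a range from 30000 nM to 160000 nM.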

Compound 4, half-maximal inhibitory concentration: > 50000 nM
Compound 4 ended at the assay's limit (the forecaster's own chance of this, stated with the estimate: 60%); the middle value does not contradict the limit.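

In this assay, 3-bromophenyl on the nitrogen gives a second compound reported only as a limit, so this outcome no longer rests on 3-chlorophenyl in compound 3 alone: the limit of > 50000 nM in this assay, at which 2 of the 4 values shown sit.

The two readable steps are an at least 1.2-fold higher number from compound 1 to compound 4 (0.08 log units; that floor lies within the scatter) and an at least 1.5-fold higher number from compound 2 to compound 4 (0.18 log units; that floor lies within the scatter); each is only a floor, so the data neither show nor exclude a real loss when 3-bromophenyl replaces 4-methoxyphenyl or 4-chlorophenyl. The step from compound 3 to compound 4, bromo in place of chloro, cannot be read, as both compounds are reported only as limits.

On these data alone, the true numbers for compound 3 and compound 4 remain unknown, so the series gives no ranking of 3-chlorophenyl against 3-bromophenyl, nor a measured comparison of either with its 4-substituted partner. Also open, as far as these compounds go, is whether 4-bromophenyl would stay with compound 2 or go to the limit, and whether a morpholine or a carboxylic acid on this phenyl ring would move the number well clear of the values seen so far.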